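The source may report more compounds than this note shows. Statements on the series, on what has been measured and on what is new or still open speak of the compounds shown alone.

In a functional assay on DU-145 cells (Homo sapiens) for inhibition, read by trypan blue exclusion, with a stated time of 96 h (on this read-out higher numbers stand for weaker inhibition of growth and lower numbers for stronger inhibition of growth), compound 1 `COc1ccc(/C=C(/Sc2ccc(C)cc2)C(=O)c2ccc(Br)cc2)cc1` gives 50000 nM, and compound 2 `Cc1ccc(S/C(=C/c2ccc(-c3ccccc3)cc2)C(=O)c2ccc(Br)cc2)cc1` gives 50000 nM. Among the compounds with values here, compound 2 therefore stands level with compound 1, the only other compound measured so far. The next compound, compound 3 `Cc1ccc(S/C(=C/c2ccc(N(C)C)cc2)C(=O)c2ccc(Br)cc2)cc1`, keeps the rest of compound 2 and alters one group: dimethylamino in place of phenyl on an aromatic carbon. Dimethylamino thus takes the place of phenyl on an aromatic carbon, para to a large group.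

Within the data shown here, only one measured step bears on this change. The step of no change at the digits printed from compound 1 to compound 2 (within the scatter) put phenyl in place of methoxy on the same aromatic carbon, and it stayed within the scatter of this assay. Among the measured compounds shown here, no measurement yet shows how dimethylamino behaves at this carbon, and a single step is thin evidence. Going by that step no change at the digits printed from compound 1 to compound 2 (within the scatter), no shift beyond the scatter is expected in either direction, and the expected step of a 1.3-fold lower number from compound 2 to compound 3 (0.10 log units; within the scatter) is correspondingly small. The range is nevertheless left wider on the side of stronger inhibition of growth. For compound 3 the estimated value is 40000 nM, with an expected range from 10000 nM to 70000 nM.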

Compound 3, concentration for 50% growth inhibition: > 100000 nM
Compound 3: only a limit was reported (the forecaster's own chance of this, stated with the estimate: 25%); middle value at least 2.5-fold (0.39 log units) from the limit.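

In this assay compound 3 gives > 100000 nM, and this value is a limit of the assay, not a number: the limit of > 100000 nM in this assay, at which 1 of the 3 values shown sits. At this aromatic carbon, the change to dimethylamino can be read only as a floor, both as an at least 2.0-fold higher number from compound 2 to compound 3 (0.30 log units; that floor lies within the scatter) and as an at least 2.0-fold higher number from compound 1 to compound 3 (0.30 log units; that floor lies within the scatter). Unlike methoxy and phenyl, which showed no change at the digits printed from compound 1 to compound 2 (within the scatter), dimethylamino gives a result with no upper end, but these floors do not establish a shift beyond the scatter, and the limit does not tell how far compound 3 lies from the other two compounds.

The compounds shown leave open whether a primary amine, a hydroxyl group or a chlorine on this aromatic carbon would read like methoxy and phenyl or would also end at a limit. They also leave open whether dimethylamino would give the same kind of result with a chlorine in place of the bromine on the shared core.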